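Swapping Chloro for Tert-Butyl on a Hydroxamic Acid

The source may report more compounds than this note shows. Statements on the series, on what has been measured and on what is new or still open speak of the compounds shown alone.

- Compound 1 `Cc1ccccc1CN1CC=C(CCC(=O)NO)C1=O` gives 4620 nM in a functional assay on PC-3 cells (Homo sapiens) for inhibition, read by sulforhodamine B assay; on this read-out lower numbers stand for stronger inhibition of growth and higher numbers for weaker inhibition of growth.
- Compound 2 `Cc1cccc(CN2CC=C(CCC(=O)NO)C2=O)c1` gives 4620 nM in this assay.
- Compound 3 `O=C(CCC1=CCN(CCCc2ccc(Cl)cc2)C1=O)NO` gives 3480 nM in this assay.

Compound 3 has the lowest of the three numbers, but its gaps to compound 1 and to compound 2 both lie within the scatter, so the three cannot be ranked against one another. Compound 4 `CC(C)(C)c1ccc(CCCN2CC=C(CCC(=O)NO)C2=O)cc1` keeps the core of compound 3 and differs in one place: tert-butyl in place of chloro on an aromatic carbon. For the measured compounds named here, no measured pair shows a step of this kind, so the expectation rests on the narrow spread seen so far. The expected step in this assay is small, within the scatter: a 1.0-fold higher number from compound 3 to compound 4 (0.00 log units; within the scatter). For compound 4 the estimate is 3500 nM, with a range from 1200 nM to 10000 nM.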

Compound 4, concentration for 50% growth inhibition: 3480 nM
Compound 4: the middle estimate sits 1.0-fold (0.00 log units) above what was measured; the measured number falls inside the stated range.
By their numbers in this assay, from the lowest: compounds 3, 4, 1 and 2 (each within the scatter of the next).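

In this assay there is no change at the digits printed from compound 3 to compound 4 (within the scatter) when tert-butyl, with 4 heavy atoms, takes the place of chloro, with 1 heavy atom. This position, on an aromatic carbon para to a large group, therefore tolerates this larger carbon-only group in this assay without a shift in the number. No available measurement explains this result.

Only these two groups can be compared here at this position. Going by these compounds, whether an amine or a carboxylic acid would also leave the number unchanged remains open.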